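The compounds below may be only part of what the source reports. "The series", "measured", "known", "first", "only" and "open" are said of these compounds alone.

Compound 1, `O=C(CN1CCC(c2cccc[n+]2[O-])CC1)NC1CCCCC1`, was tested in a functional assay on HEK293 cells for agonist activity at D(4) dopamine receptor (Homo sapiens), read by FLIPR (a higher number here means that more compound is needed for the effect, a lower number that less compound is needed), where compound 1 gives 294 nM. Among the three compounds measured so far, that number is the second highest. Compound 3, `CCOc1cccc(C(=O)NCN2CCC(c3cccc[n+]3[O-])CC2)c1`, gives 324 nM, which lies within the scatter of compound 1. Compound 2, `Cc1cccc(C(=O)NCN2CCC(c3nccs3)CC2)c1`, gives 9.8 nM, a lower number that stands beyond the scatter from compound 1. Compound 4, `O=C(CN1CCC(c2cccc[n+]2[O-])CC1)Nc1cc(Cl)cc(Cl)c1`, has not yet been measured. It differs from compound 1 in one place: 3,5-dichlorophenyl in place of cyclohexyl on an amide-type nitrogen. Going by the values given here, no measured pair shows the effect of this particular change, so the size of the step can only be estimated. The step of a 1.5-fold lower number from compound 1 to compound 4 (0.17 log units; within the scatter) is expected to be small, possibly toward a lower number. For compound 4 the estimate is 200 nM, with a range from 50 nM to 900 nM.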

Compound 4, half-maximal effective concentration: 160 nM
The estimate for compound 4 lay 1.3-fold (0.10 log units) above the measured number; the range from low to high includes it.
By their numbers in this assay, from the lowest: compound 2; then compounds 4, 1 and 3 (each within the scatter of the next, the first and the last beyond it).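

Placing 3,5-dichlorophenyl in place of cyclohexyl on the amide-type nitrogen gives a 1.8-fold lower number from compound 1 to compound 4 (0.26 log units; within the scatter) in this assay. Going by these compounds alone, this is the first direct reading at this position: a non-aromatic carbon ring and an aromatic ring carrying two chlorines are not told apart here, so the position takes either without a step beyond the scatter. Nothing measured here gives a reason for this result. Still open, as far as these compounds go, is whether plain phenyl, with no chlorine, would give a similar number, and whether a carboxylic acid or an amine on a longer chain would also fit at this position.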